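This account rests on a few compounds, and the source may have more. Where it says the series, first, only, none or still open, it means among the compounds named here.

Compound 1 `Cc1cc(OCC(=O)N(C)C)cc(C)c1-c1cccc(COc2ccc(OCC(=O)O)c(F)c2)c1` has in a functional assay on CHO cells for agonist activity at Free fatty acid receptor 1 (Homo sapiens), read by FLIPR and calcium flux (a higher number here means that more compound is needed for the effect, a lower number that less compound is needed), only the entry "not determined" (no result reported), so nothing can be said of how much of it is needed. Compound 2 `Cc1cc(OCCCS(C)(=O)=O)ccc1-c1cccc(COc2ccc(OCC(=O)O)c(F)c2)c1`, a close relative, gives 43.6 nM in this assay. Compound 3 `COCCOc1cc(C)c(-c2cccc(COc3ccc(OCC(=O)O)c(F)c3)c2)c(C)c1` differs from compound 1 by methoxymethyl in place of dimethylcarbamoyl on a saturated chain carbon bound to an oxygen on an aromatic ring. Going by the values given here, no measured step of this kind is at hand, and the change is expected to shift the result in this assay by no more than the usual scatter, in either direction. Compound 3 is therefore estimated at 50 nM, with a range from 15 nM to 160 nM.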

Compound 3, half-maximal effective concentration: 104 nM
Beside the measured number, compound 3's estimate is 2.1-fold (0.32 log units) below it; the measured number falls inside the stated range.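

Going by these compounds alone, compound 1 has no single number in this assay to set against compound 3, so no step between them can be read. On these data alone, what replacing dimethylcarbamoyl with methoxymethyl does to the result stays open, and no supporting evidence bears on it.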